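Chloro to Bromo on the Aryl Ring of Compound 2

This account rests on a few compounds, and the source may have more. Where it says the series, first, only, none or still open, it means among the compounds named here.

Measured compounds:
compound 1, `Nc1nc(N2CCCC2)sc1C(=O)/C=C/c1ccc(Br)cc1`, 41.3 ug/mL
compound 2, `Nc1nc(N2CCCCC2)sc1C(=O)/C=C/c1ccc(Cl)cc1`, 19.5 ug/mL

Compound 1 is `Nc1nc(N2CCCC2)sc1C(=O)/C=C/c1ccc(Br)cc1`. In a functional assay on MCF7 cells (Homo sapiens) for antiproliferative activity, read by MTT assay, with a stated time of 48 h (a lower number here means a stronger inhibitor, a higher number a weaker inhibitor), compound 1 gives 41.3 ug/mL. Compound 2 is `Nc1nc(N2CCCCC2)sc1C(=O)/C=C/c1ccc(Cl)cc1`, and in this assay compound 2 gives 19.5 ug/mL. Of the two numbers, compound 2 stands lowest; its nearest neighbour is compound 1, whose number lies beyond the scatter above it. Compound 1 and compound 2 differ in more than one place, so their two values show only where each stands.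

Compound 3 is `Nc1nc(N2CCCCC2)sc1C(=O)/C=C/c1ccc(Br)cc1`. It differs from compound 2 by bromo in place of chloro on an aromatic carbon; cut one bond further out, the change reads 4-chlorophenyl to 4-bromophenyl. Going by the values given here, no step between measured compounds isolates this exchange, so nothing measured here speaks to its size. A swap of one halogen for another on an aromatic carbon usually moves a number of this kind little, and the step from compound 2 to compound 3 is expected to be small, possibly toward a slightly higher number, and likely within the scatter.

For compound 3 in this assay, the estimated value is 25 ug/mL, within a range of 10 ug/mL to 60 ug/mL, which corresponds to an expected step of a 1.3-fold higher number from compound 2 to compound 3 (0.11 log units; within the scatter).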

Compound 3, half-maximal inhibitory concentration: 25.6 ug/mL
Estimate against measurement, compound 3: 1.0-fold (0.01 log units) below, and the stated range covers the measured number.
By their numbers in this assay, from the lowest: compounds 2, 3 and 1 (each within the scatter of the next, the first and the last beyond it).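

In this assay, going by these compounds alone, bromo in place of chloro on the aromatic carbon gives a 1.3-fold higher number from compound 2 to compound 3 (0.12 log units; within the scatter), so for the first time this halogen exchange is seen on its own, with the piperidin-1-yl group held constant, and at this place it does not move the number beyond the scatter. Compound 3 also joins compound 1 and compound 2 by one change each, and with the 4-bromophenyl group held constant, piperidin-1-yl in place of pyrrolidin-1-yl gives a 1.6-fold lower number from compound 1 to compound 3 (0.21 log units; within the scatter), so neither single change, taken alone, separates its pair beyond the scatter. Nothing available here accounts for the size of either step.

The compounds shown leave open whether other groups on this aromatic carbon, such as fluoro, methoxy or a carboxylic acid, would give a step beyond the scatter, since only two halogens have been compared at this place. They also leave open how morpholin-4-yl or an open-chain dimethylamino group would read in place of piperidin-1-yl, and whether chloro paired with pyrrolidin-1-yl would follow the same two steps.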